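Amide variation on a butoxy pyrazole carboxamide in rat paw edema

The source may report more compounds than this note shows. Statements on the series, on what has been measured and on what is new or still open speak of the compounds shown alone.

The measured compounds:
compound 1 `CCCCOc1cc(C(=O)NCC)nn1-c1ccccc1`, 0%
compound 2 `CCCCOc1cc(C(=O)N(C)C)nn1-c1ccccc1`, 18.7%
compound 3 `CCCCNC(=O)c1cc(OCCCC)n(-c2ccccc2)n1`, 43.3%

In a functional assay on the whole organism (strain Wistar) for inhibition, with Rattus norvegicus as the target, read by paw edema, with stated times of 30 min and 3 h, at a dose of 100 mg/kg by the oral route (a lower number here means less inhibition, a higher number more inhibition at the dose given (going by the name of the read-out)), compound 3 stands highest of the three: compound 2 is nearest, compound 1 furthest, and both steps to it lie beyond the scatter, a number 24.6 percentage points higher from compound 2 to compound 3 (beyond the scatter) and a number 43.3 percentage points higher from compound 1 to compound 3 (beyond the scatter).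

Compound 4 `CCCCOc1cc(C(=O)N2CCCCC2)nn1-c1ccccc1` has not yet been measured. Its change from compound 3 is piperidin-1-yl in place of butylamino on a carbonyl carbon. Going by the values given here, the steps that bear on it all sit on the same carbonyl carbon: a number 18.7 percentage points higher from compound 1 to compound 2 (beyond the scatter) and a number 24.6 percentage points higher from compound 2 to compound 3 (beyond the scatter). Compound 2, whose dimethylamino also carries no hydrogen-bond donor, gives 18.7%, below compound 3. The piperidin-1-yl of compound 4 likewise removes the donor while adding a ring, so a modest downward step is expected, a number 18.3 percentage points lower from compound 3 to compound 4 (beyond the scatter), with compound 2 marking where it could end. Compound 4 is thus estimated at 25%, in the range 5% to 48%.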

Compound 4, a percentage reported as inhibition, in the whole organism at one dose (the size of the read-out at that dose, not a potency): 15.6%
For compound 4 the middle estimate is 9.4 percentage points above the measured one, within the range that was stated.
By their numbers in this assay, from the lowest: compound 1; then compounds 4 and 2 (each within the scatter of the next); then compound 3.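

In this assay, the piperidin-1-yl amide does not hold the level of the butylamino amide (a number 27.7 percentage points lower from compound 3 to compound 4 (beyond the scatter)), so a ring on this carbonyl carbon cannot stand in for the four-carbon chain. Against dimethylamino the ring shows no difference that can be told apart (a number 3.1 percentage points lower from compound 2 to compound 4 (within the scatter)), which places the two amides without an amide hydrogen together. The amide hydrogen alone does not sort the series, however: the ethylamino of compound 1 carries it, yet the step to the ring still goes upward (a number 15.6 percentage points higher from compound 1 to compound 4 (beyond the scatter)), and compound 1 thus stands against such a reading.

The compounds shown leave open whether a hexylamino chain would go beyond butylamino and whether a morpholin-4-yl ring would read differently from piperidin-1-yl. No measurement at hand accounts for any of these steps.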